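From Amide to Urea on a Shared Core

The source may hold more compounds than are shown below. What is called first, only, known or untested is meant among the compounds shown, and "the series" means these compounds.

compound 1 `COc1cc(-c2nn(-c3cccc(NC(=O)c4cccc(C(F)(F)F)c4)c3)cc2-c2ccncc2)ccc1Cl` — > 50000 nM
compound 2 `COc1cc(-c2nn(-c3cccc(NC(=O)c4ccc(Cl)c(C(F)(F)F)c4)c3)cc2-c2ccncc2)ccc1Cl` — > 32500 nM

In a functional assay on KM12 cells (Homo sapiens) for inhibition, read by sulforhodamine B assay, with a stated time of 48 h (a higher number here means a weaker inhibitor of growth, a lower number a stronger inhibitor of growth), compound 1 gives > 50000 nM, which is a limit of the assay and not a number. Compound 2 gives > 32500 nM, likewise a limit. The step that the two limits leave unreadable from compound 1 to compound 2 is therefore unreadable, and compound 2 stands at the limit of > 32500 nM in this assay, at which 1 of the 2 values shown sits. Compound 3 `COc1cc(-c2nn(-c3cccc(NC(=O)Nc4ccc(Cl)c(C(F)(F)F)c4)c3)cc2-c2ccncc2)ccc1Cl` differs from compound 2 by (4-chloro-3-(trifluoromethyl)phenyl)amino in place of 4-chloro-3-(trifluoromethyl)phenyl on a carbonyl carbon. Going by the values given here, no measured step bears on this change, so no step beyond the scatter can be expected in either direction. Compound 3 is estimated at 40000 nM, within 10000 nM to 100000 nM. The expected step is a step that the limit leaves unreadable from compound 2 to compound 3.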

Compound 3, concentration for total growth inhibition: 3920 nM
The estimate for compound 3 lay 10-fold (1.01 log units) above the measured number; the whole stated range lies above it.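

Going by these compounds alone, replacing 4-chloro-3-(trifluoromethyl)phenyl on the carbonyl carbon with (4-chloro-3-(trifluoromethyl)phenyl)amino turns the amide into a urea and, in this assay, gives the only value shown that is not a limit: an at least 8.2-fold lower number from compound 2 to compound 3 (0.91 log units; beyond the scatter). Counting the added chloro as well, the change from the first amide is an at least 12-fold lower number from compound 1 to compound 3 (1.10 log units; beyond the scatter). Compound 2 stands at a limit of the assay and not a number: the limit of > 32500 nM in this assay, at which 1 of the 3 values shown sits.

On these data alone, whether the urea needs its chloro group remains open. So does the effect of a methylene group or an ether oxygen in place of the urea's amino group.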